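A Second Fluorine Added to Compound 3

The compounds below may be only part of what the source reports. "The series", "measured", "known", "first", "only" and "open" are said of these compounds alone.

In an assay on J774 cells for inhibition of prostaglandin G/H synthase 1 (Mus musculus), read by immunoassay, with stated times of 15 min and 30 min (on this read-out higher numbers stand for weaker inhibition and lower numbers for stronger inhibition), three compounds have so far been tested. Compound 1 `Cc1c(C=O)cc(-c2ccc(S(C)(=O)=O)cc2)n1-c1cccc(F)c1` gives only a limit of the assay, > 10000 nM. Compound 2 `Cc1c(C=O)cc(-c2ccc(S(C)(=O)=O)cc2)n1-c1ccccc1` likewise gives a limit, > 10000 nM. Compound 3 `Cc1c(C#N)cc(-c2ccc(S(C)(=O)=O)cc2)n1-c1cccc(F)c1` also gives a limit, > 10000 nM. The change from compound 2 to compound 1 is fluoro in place of hydrogen on an aromatic carbon, and its step is a step that the two limits leave unreadable from compound 2 to compound 1. From compound 1 onward the step is a step that the two limits leave unreadable from compound 1 to compound 3. The difference between the cores of compound 2 and compound 3 is not broken down here. Within the data shown here, every value so far sits at the limit of > 10000 nM in this assay, at which 3 of the 3 values shown sit. Compound 4 `Cc1c(C#N)cc(-c2ccc(S(C)(=O)=O)cc2)n1-c1ccc(F)c(F)c1` is not yet measured; it differs from compound 3 by fluoro in place of hydrogen on an aromatic carbon. This is the same kind of change as from compound 2 to compound 1, though here the place is ortho to a fluoro group and para to a large group rather than meta to a large group. Because a step that the two limits leave unreadable from compound 2 to compound 1 has no readable size, the step is expected to be a step that the limit leaves unreadable from compound 3 to compound 4. Compound 4 is therefore estimated at 15000 nM, most likely again reported only as a limit.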

Compound 4, half-maximal inhibitory concentration: > 10000 nM
Compound 4: no number, only a limit (the forecaster's own chance of this, stated with the estimate: 85%); the middle value does not contradict the limit.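

Compound 3 and compound 4 each give only a limit of the assay, so no step can be read between them: the limit of > 10000 nM in this assay, at which 4 of the 4 values shown sit. The compounds shown leave open how strongly any of them inhibits, and whether the second fluoro group makes any difference.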